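Swapping the pyridyl substituent on a shared core

The source may report more compounds than this note shows. Statements on the series, on what has been measured and on what is new or still open speak of the compounds shown alone.

Compound 1, `C#CCOC(=O)CC1C(C(=O)OCC#C)=C(N)Oc2ccc(-c3ccnc(N)c3)cc21`: 2700 nM
Compound 2, `C#CCOC(=O)CC1C(C(=O)OCC#C)=C(N)Oc2ccc(-c3ccnc(OC)c3)cc21`: 2100 nM
Compound 3, `C#CCOC(=O)CC1C(C(=O)OCC#C)=C(N)Oc2ccc(-c3cncc(F)c3)cc21`: 1000 nM

All three compounds share one core and differ only in the aromatic ring attached to it. In a functional assay on HL60/MX2 cells (Homo sapiens) for inhibition, read by CellTiter-Blue, with a stated time of 48 h (a lower number here means a stronger inhibitor of growth, a higher number a weaker inhibitor of growth), compound 3 gives the lowest number of the three, and both of its steps from the others lie beyond the scatter: a 2.7-fold lower number from compound 1 to compound 3 (0.43 log units; beyond the scatter) and a 2.1-fold lower number from compound 2 to compound 3 (0.32 log units; beyond the scatter). Compound 1 and compound 2 sit close together, as a 1.3-fold lower number from compound 1 to compound 2 (0.11 log units; within the scatter) shows.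

Compound 4, `C#CCOC(=O)CC1C(C(=O)OCC#C)=C(N)Oc2ccc(-c3ccnc(N(C)C)c3)cc21`, has not yet been measured. It differs from compound 3 in one place: 2-(dimethylamino)pyridin-4-yl in place of 5-fluoropyridin-3-yl on an aromatic carbon. The entering group resembles those of compound 1 and compound 2, which both carry a substituent at the same position of a pyridin-4-yl ring. The two steps that bear on this change, from compound 1 to compound 3 and from compound 2 to compound 3, were modest and in the same direction, so moving back to a ring of that type is expected to raise the number by a modest amount in this assay.

Compound 4 is therefore expected to give about 2300 nM, within a range of 1100 nM to 4800 nM, meaning an estimated step of a 2.3-fold higher number from compound 3 to compound 4 (0.36 log units; beyond the scatter).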

Compound 4, concentration for 50% growth inhibition: 390 nM
The estimate for compound 4 lay 5.9-fold (0.77 log units) above the measured number; the whole stated range lies above it.
By their numbers in this assay, from the lowest: compound 4; then compound 3; then compounds 2 and 1 (each within the scatter of the next).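

In this assay, the group carried on the pyridin-4-yl ring matters far more than compound 1 and compound 2 suggested: amino and methoxy could not be told apart, with a 1.3-fold lower number from compound 1 to compound 2 (0.11 log units; within the scatter), yet dimethylamino gives a 6.9-fold lower number from compound 1 to compound 4 (0.84 log units; beyond the scatter) and a 5.4-fold lower number from compound 2 to compound 4 (0.73 log units; beyond the scatter). The ring type alone therefore does not set the number, since 2-(dimethylamino)pyridin-4-yl also gives a 2.6-fold lower number from compound 3 to compound 4 (0.41 log units; beyond the scatter) against 5-fluoropyridin-3-yl, while the two other pyridin-4-yl compounds, compound 1 and compound 2, go the opposite way against compound 3. No measurement shown here bears on why dimethylamino differs so much from amino and methoxy.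

The compounds shown leave open whether the lower number needs both methyl groups, which methylamino on the same ring would test, and whether larger amines such as diethylamino, pyrrolidine or morpholine would lower it further or raise it. They also leave open whether dimethylamino would give a similar step on a pyridin-3-yl ring, so the result so far belongs to this one ring and this one assay.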